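Methoxy replaces a sulfonamide on the shared core

A few compounds are considered here, and "the series" means these few. Any claim that something is new, unique, unknown or untested is made for them only; others in the source may bear on it.

Measured compounds in a functional assay on CHO cells for agonist activity at Alpha-1A adrenergic receptor (Homo sapiens), read by FLIPR and calcium flux; on this read-out higher numbers stand for larger maximal responses and lower numbers for smaller maximal responses:
compound 1 `Cc1n[nH]cc1-c1cccc2c1CCC2c1ncc[nH]1` gives 91%
compound 2 `CCCS(=O)(=O)Nc1cccc2c1CCC2c1ncc[nH]1` gives 54%
compound 3 `Cc1c(OCC2=NCCN2)ccc(Cl)c1NS(C)(=O)=O` gives 60%

Compound 2 stands lowest of the three numbers. Its nearest neighbour is compound 3, which gives a number higher by an amount that lies within the scatter, so the two cannot be ordered. Compound 1 stands far above it: the step of a number 37 percentage points lower from compound 1 to compound 2 (beyond the scatter) is beyond the scatter and large.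

Compound 4 `COc1cccc2c1CCC2c1ncc[nH]1` is not yet measured. It differs from compound 2 in one place: methoxy in place of (propylsulfonyl)amino on an aromatic carbon.

Among the compounds with values here, only one measured step touches this position, the exchange from compound 1 to compound 2, and it shows that the (propylsulfonyl)amino group coincides with the lowest maximal response of the set. Within the data shown here, no measured compound carries a methoxy at this place, so the size of the coming step rests on weak ground. The removal of the (propylsulfonyl)amino group is expected to shift the response upward, toward the level of compound 1, but by a smaller step than a number 37 percentage points lower from compound 1 to compound 2 (beyond the scatter), with a range that also allows no change beyond the scatter. The step expected is a number 16 percentage points higher from compound 2 to compound 4 (beyond the scatter).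

The estimate for compound 4 in this assay is 70%, expected to lie between 48% and 92%.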

Compound 4, largest response reached (Emax), in percent of the reference or control that the assay uses: 65%
The estimate for compound 4 lay 5 percentage points above the measured number, within the range that was stated.
By their numbers in this assay, from the lowest: compounds 2, 3 and 4 (each within the scatter of the next, the first and the last beyond it); then compound 1.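

In this assay the exchange of (propylsulfonyl)amino for methoxy gives a number 11 percentage points higher from compound 2 to compound 4 (beyond the scatter) and so adds a second measured change at this aromatic carbon of the shared core. The group that enters has 0 hydrogen-bond donors and 2 heavy atoms against the 1 hydrogen-bond donor and 7 heavy atoms of the group that leaves, so among these compounds a sizeable maximal response does not need the larger sulfonyl-bearing group or a donor at this place. The methoxy compound still falls short of the pyrazole compound, with a number 26 percentage points lower from compound 1 to compound 4 (beyond the scatter) as the second step, which places the three groups at this position in a clear order, with 3-methyl-1H-pyrazol-4-yl on top, methoxy in the middle and (propylsulfonyl)amino last.

On these data alone, it remains open whether a simple amine, a hydroxyl, a longer ether chain such as propoxy or another five-membered aromatic ring in place of the pyrazole would reach the level of compound 1 or stay near that of compound 4. Nothing presented here offers measured support for explaining why the response moves as it does across these groups.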